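Dropping the Para-Fluoro from a Thiazolyl Hydrazone

The compounds below may be only part of what the source reports. "The series", "measured", "known", "first", "only" and "open" are said of these compounds alone.

Measured compounds:
compound 1, `Clc1ccc(-c2csc(N/N=C/c3cccs3)n2)cc1`, 82.8%
compound 2, `Fc1ccc(-c2csc(N/N=C/c3ccc(Cl)cc3Cl)n2)cc1`, 88.4%
compound 3, `Fc1ccc(-c2csc(N/N=C/c3cccs3)n2)cc1`, 84.2%

In a functional assay, read by spectrophotometry, with a stated time of 15 min, tested at 20 ug/mL (a higher number here means a stronger effect of the compound at the concentration tested, a lower number a weaker effect), compound 2 gives 88.4%. Its number is the largest of the three, yet the gaps to compound 3 and to compound 1 both lie within the usual scatter, so the three compounds cannot be ranked on these data. Among the compounds with values here, the only measured step at the same place is a number 1.4 percentage points higher from compound 1 to compound 3 (within the scatter), a swap of one halogen for another that left the read-out essentially unchanged.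

Compound 4, `Clc1ccc(/C=N/Nc2nc(-c3ccccc3)cs2)c(Cl)c1`, differs from compound 2 by hydrogen in place of fluoro on an aromatic carbon. Within the data shown here, no measured step removes a halogen entirely, so the expectation rests on the halogen swap alone. Compound 4 is therefore expected to show a number 4.4 percentage points lower from compound 2 to compound 4 (within the scatter), a step not beyond the scatter, giving an estimated 84% with a range from 74% to 92%.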

Compound 4, a percentage reported as inhibition, at one concentration (the size of the read-out at that concentration, not a potency): 78.1%
Compound 4: middle estimate off by 5.9 percentage points, on the high side, within the range that was stated.
By their numbers in this assay, from the lowest: compounds 4, 1, 3 and 2 (each within the scatter of the next, the first and the last beyond it).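

In this assay, within the data shown here, the change from 4-fluorophenyl to phenyl gives a number 10.3 percentage points lower from compound 2 to compound 4 (beyond the scatter) and is the only step here beyond the scatter. At this position, the halogen swap in a number 1.4 percentage points higher from compound 1 to compound 3 (within the scatter) stayed within the scatter, though it was read on a pair that differs from compound 2 elsewhere in the molecule. Nothing available gives a cause for the new step.

From the compounds shown here alone, whether a methoxy group or an amine at this place would read closer to fluoro or to hydrogen remains open. So does whether losing the fluoro from compound 3 would give a similar step.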